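The compounds below may be only part of what the source reports. "The series", "measured", "known", "first", "only" and "open" are said of these compounds alone.

Compound 1, `COc1cc2cc(Oc3ccc(NC(=O)Nc4ccccc4)cc3)c(C)nc2cc1OC`, gives 58.4% in a functional assay on A549 cells (Homo sapiens) for inhibition, read by sulforhodamine B assay, with a stated time of 48 h, tested at 10 uM; on this read-out lower numbers stand for a stronger effect and higher numbers for a weaker effect at the one concentration tested.
Compound 2, `COc1cc2cc(Oc3ccc(NC(=O)Nc4ccc(C)cc4)cc3)c(C)nc2cc1OC`, gives 102%.

Of these two numbers, compound 2 stands highest in this assay, which here means the weaker effect. Compound 3, `COc1cc2cc(Oc3ccc(NC(=O)Nc4ccc(C(F)(F)F)cc4)cc3)c(C)nc2cc1OC`, is not yet measured; it differs from compound 2 by trifluoromethyl in place of methyl on an aromatic carbon. Among the measured compounds shown here, the one measured step that bears on it, a number 43.6 percentage points higher from compound 1 to compound 2 (beyond the scatter), changed the same aromatic carbon, but no measured compound carries trifluoromethyl there. Since compound 2 already sits near the weak end of the scale, the expected step is a number 7 percentage points lower from compound 2 to compound 3 (within the scatter), within the scatter. Compound 3 is estimated at 95%, expected between 72% and 112%.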

Compound 3, a percentage reported as activity, at one concentration (the size of the read-out at that concentration, not a potency): 32.4%
Compound 3: the middle estimate sits 62.6 percentage points above what was measured; the whole stated range lies above it.
By their numbers in this assay, from the lowest: compound 3; then compound 1; then compound 2.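

In this assay, replacing methyl with trifluoromethyl gives a number 69.6 percentage points lower from compound 2 to compound 3 (beyond the scatter), so the identity of the group on this aromatic carbon matters greatly. Putting trifluoromethyl in place of hydrogen gives a number 26 percentage points lower from compound 1 to compound 3 (beyond the scatter), showing that a group here can strengthen the effect as well as weaken it, whereas methyl had shown only a loss. Nothing available explains why these two groups differ so sharply. The compounds shown leave open whether a chlorine atom, a methoxy group or a nitrile on this carbon would behave like trifluoromethyl or like methyl. They also leave open how trifluoromethyl would act elsewhere on that ring.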